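Changing the aryl group on the amide nitrogen

The source may hold more compounds than are shown below. What is called first, only, known or untested is meant among the compounds shown, and "the series" means these compounds.

Compound 1 (`O=C(CCc1cccc2c1B(O)OC2)Nc1ccc(F)cc1`): 440 nM (measured)
Compound 2 (`Cc1ccc(NC(=O)CCc2cccc3c2B(O)OC3)cc1`): 1100 nM (measured)

Going by the values given here, in a functional assay on MDA-MB-231 cells (Homo sapiens) for antiproliferative activity, read by MTT assay, with a stated time of 72 h (on this read-out higher numbers stand for weaker inhibition and lower numbers for stronger inhibition), compound 2 stands at 1100 nM as the higher of only two numbers, which makes it the weaker inhibitor of the pair. Among the compounds with values here, the one measured step is a 2.5-fold higher number from compound 1 to compound 2 (0.40 log units; beyond the scatter) (modest in size), and it swaps fluoro for methyl on an aromatic carbon.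

Compound 3 (`O=C(CCc1cccc2c1B(O)OC2)Nc1cccc(Br)c1`) has not yet been measured. It differs from compound 2 in one place: 3-bromophenyl in place of 4-methylphenyl on an amide-type nitrogen. Within the data shown here, the measured step bears on this change only loosely, since no bromo compound has a number yet. A small shift toward a lower number is expected, resting only on compound 1, whose 440 nM came with fluoro rather than methyl on the ring. With so little data, the shift may not exceed the usual scatter. The estimated step is a 1.7-fold lower number from compound 2 to compound 3 (0.23 log units; within the scatter) (an expectation only). Compound 3 is expected at about 650 nM (estimated range 220 nM to 1900 nM).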

Compound 3, half-maximal inhibitory concentration: 720 nM
For compound 3 the middle estimate is 1.1-fold (0.04 log units) below the measured one; low and high end bracket the measured number.
By their numbers in this assay, from the lowest: compounds 1, 3 and 2 (each within the scatter of the next, the first and the last beyond it).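

In this assay the amide-type nitrogen now carries a third aryl group, which gives a 1.5-fold lower number from compound 2 to compound 3 (0.18 log units; within the scatter) and also a 1.6-fold higher number from compound 1 to compound 3 (0.21 log units; within the scatter) as the two new comparisons. Both steps lie within the usual scatter, so compound 3 cannot be separated from either neighbour, even though compound 1 and compound 2 do differ from each other beyond the scatter. At this position, then, 3-bromophenyl reads the same as both 4-fluorophenyl and 4-methylphenyl, so changing the substituent and its place on the ring together gives no shift that can be read, and compound 3 adds no clear order among the three aryl groups.

Still open, going by these compounds, is how far this tolerance extends, for instance whether a pyridine ring, a carboxylic acid on the phenyl ring or a simple amine in place of the aryl group would keep the number in the same range. Nothing available here explains why the three values fall where they do.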